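The compounds below may be only part of what the source reports. "The series", "measured", "known", "first", "only" and "open" are said of these compounds alone.

Measured compounds:
compound 1, `CCCc1ccc2[nH]c(=O)c(CN(Cc3ccc(F)cc3)Cc3ccc(C(C)(C)C)cc3)cc2c1` — 8400 nM
compound 2, `Cc1ccc2[nH]c(=O)c(CN(Cc3cccc(F)c3)Cc3ccc4ccccc4c3)cc2c1` — > 5000 nM
compound 3, `Cc1ccc2[nH]c(=O)c(CN(Cc3ccc(OCC(=O)OC(C)(C)C)cc3)Cc3ccc(C(C)(C)C)cc3)cc2c1` — > 10000 nM

In a toxicity assay on MDCK cells (Canis lupus familiaris) for cytotoxicity, read by crystal violet staining, with a stated time of 48 h (a lower number here means that less compound is tolerated, a higher number that more compound is tolerated), compound 1 gives 8400 nM, the only numerical result in the set. For compound 2 the assay reports only a limit, > 5000 nM. For compound 3 the assay likewise reports only a limit, > 10000 nM, so compound 3 stands at the limit of > 10000 nM in this assay, at which 1 of the 3 values shown sits; one further result in the set sits at the limit of > 5000 nM in this assay, at which 1 of the 3 values shown sits.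

Compound 4, `Cc1ccc2[nH]c(=O)c(CN(Cc3ccc(C(N)=O)cc3)Cc3ccc(C(C)(C)C)cc3)cc2c1`, differs from compound 3 by carbamoyl in place of (tert-butoxycarbonyl)methoxy on an aromatic carbon. Going by the values given here, no step between measured compounds covers this change. The expectation for the step from compound 3 to compound 4 in this assay is none beyond the usual scatter, a step that the limit leaves unreadable from compound 3 to compound 4. Compound 4 is therefore expected to give 12000 nM, within 4000 nM to 30000 nM, most likely again reported as a limit.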

Compound 4, half-maximal cytotoxic concentration: > 5000 nM
Compound 4: only a limit was reported (the forecaster's own chance of this, stated with the estimate: 70%); the middle value does not contradict the limit.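

In this assay compound 3 stands at the limit > 10000 nM. Going by these compounds alone, compound 4 stands at the limit > 5000 nM, so no step between these two compounds can be read. On these data alone, whether carbamoyl in place of (tert-butoxycarbonyl)methoxy shifts the tolerated concentration remains open.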